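This account rests on a few compounds, and the source may have more. Where it says the series, first, only, none or still open, it means among the compounds named here.

In a functional assay on NCI-H23 cells (Homo sapiens) for inhibition, read by sulforhodamine B assay, with a stated time of 48 h, tested at 10 uM (a lower number here means a stronger effect, a higher number a weaker effect of the compound at the concentration tested), compound 1 `COc1cc(Cl)cc(-c2nn(-c3cccc(NC(=O)Nc4ccc(Cl)c(C(F)(F)F)c4)c3)cc2-c2ccncc2)c1` gives 0.3%, and compound 2 `COc1cc(Cl)cc(-c2nn(-c3cccc(NC(=O)Nc4cccc(C(F)(F)F)c4)c3)cc2-c2ccncc2)c1` gives -5.1%. Compound 2 stands at one end of these two numbers, but the gap that separates it from compound 1 is a number 5.4 percentage points lower from compound 1 to compound 2 (within the scatter), so on this assay the two compounds cannot be told apart. Compound 3 `COc1cc(Cl)cc(-c2nn(-c3cccc(NC(=O)c4cccc(C(F)(F)F)c4)c3)cc2-c2ccncc2)c1` differs from compound 2 in one place: 3-(trifluoromethyl)phenyl in place of (3-(trifluoromethyl)phenyl)amino on a carbonyl carbon. Within the data shown here, no measured step touches this part of the structure; the only step known, hydrogen in place of chloro on an aromatic carbon elsewhere in the molecule, is of a different kind and itself stayed within the scatter. There is thus no ground to expect a move beyond the scatter. The estimated step is a number 2.1 percentage points higher from compound 2 to compound 3 (within the scatter). Compound 3 is therefore expected to give -3%, with a range from -20% to 15%.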

Compound 3, a percentage reported as activity, at one concentration (the size of the read-out at that concentration, not a potency): 55.7%
For compound 3 the middle estimate is 58.7 percentage points below the measured one, and the stated range ends below it.
By their numbers in this assay, from the lowest: compounds 2 and 1 (each within the scatter of the next); then compound 3.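

On the carbonyl carbon, the amino nitrogen turns out to matter a great deal: in this assay, replacing (3-(trifluoromethyl)phenyl)amino with 3-(trifluoromethyl)phenyl gives a number 60.8 percentage points higher from compound 2 to compound 3 (beyond the scatter), a far weaker effect at the concentration tested. Replacing (4-chloro-3-(trifluoromethyl)phenyl)amino with the same group gives a step of similar size, a number 55.4 percentage points higher from compound 1 to compound 3 (beyond the scatter), so this change matters much more than the chloro change, which stayed within the scatter. Nothing available here shows what lies behind this loss of effect.

The compounds shown leave open whether the nitrogen itself or the amide hydrogen on it accounts for the difference. A methylamino link or a methylene group on the carbonyl carbon would help separate these two possibilities.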